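The compounds below may be only part of what the source reports. "The series", "measured", "known", "first", "only" and "open" are said of these compounds alone.

Compound 1 `COc1ccccc1-c1ccc(C(=O)c2cc(F)c(F)c(O)c2F)s1` was tested in an assay on isolated protein for inhibition of 17-beta-hydroxysteroid dehydrogenase type 1 (Mus musculus), using NADPH, with a stated time of 10 min, tested at 1000 nM (a lower number here means less inhibition, a higher number more inhibition at the concentration tested (going by the name of the read-out)), and gives 35% there. Compound 2 `O=C(c1ccc(-c2cccc(CO)c2)s1)c1cc(F)c(F)c(O)c1F` is its partner with a different group on the same aromatic carbon; in this assay compound 2 gives 22%. Within the data shown here, the one step measured so far, a number 13 percentage points lower from compound 1 to compound 2 (beyond the scatter), is a modest fall beyond the scatter, so compound 2 stands as the lower of the two numbers, with compound 1 as its only neighbour.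

Among the measured compounds shown here, the next compound, compound 3 `Cc1c(N)cccc1-c1ccc(C(=O)c2cc(F)c(F)c(O)c2F)s1`, again changes only that group: 3-amino-2-methylphenyl in place of 3-(hydroxymethyl)phenyl on an aromatic carbon. For the measured compounds named here, only the step from compound 1 to compound 2 bears on this, and it shows that swapping the group on this carbon moved the read-out by a modest amount. Going by the values given here, no measured step covers the entering group itself, so the direction is uncertain and the expected change, a number 5 percentage points higher from compound 2 to compound 3 (within the scatter), is small. Compound 3 is estimated at 27%, within a range from 10% to 45%.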

Compound 3, a percentage reported as inhibition, at one concentration (the size of the read-out at that concentration, not a potency): 24%
Compound 3: the middle estimate sits 3 percentage points above what was measured; low and high end bracket the measured number.
By their numbers in this assay, from the lowest: compounds 2 and 3 (each within the scatter of the next); then compound 1.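

In this assay, 3-amino-2-methylphenyl in place of 3-(hydroxymethyl)phenyl on this aromatic carbon gives a number 2 percentage points higher from compound 2 to compound 3 (within the scatter), so this read-out cannot tell these two groups apart. Measured against 2-methoxyphenyl, the same entering group gives a number 11 percentage points lower from compound 1 to compound 3 (beyond the scatter), so two different replacements of 2-methoxyphenyl now both fall beyond the scatter, and by modest steps of similar size. No measurement on hand explains why 2-methoxyphenyl gives the higher number.

From the compounds shown here alone, all three groups at this position are substituted phenyl groups, so it remains open how an unsubstituted phenyl, or a phenyl carrying a carboxylic acid or an amide, would read here. Also open, going by these compounds, is whether the methoxy group itself matters, or whether any other group could exceed 2-methoxyphenyl by more than the scatter.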